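The source may report more compounds than this note shows. Statements on the series, on what has been measured and on what is new or still open speak of the compounds shown alone.

Notes on the series in an ADME assay on KB cells (Homo sapiens) for cytotoxicity; a lower number here means a stronger inhibitor, a higher number a weaker inhibitor. Compound 1 `[C-]#[N+][C@@H]1[C@H](C(C)C)CC[C@@H](C)[C@@]12C=C(C)CC2` gives only a limit, > 20 ug/mL. Compound 2 `CC1=C[C@]2(CC1)[C@H](C)CC[C@@H](C(C)C)[C@H]2N=C=S` likewise returns a limit, > 20 ug/mL. The step that the two limits leave unreadable from compound 1 to compound 2 therefore cannot be sized. Compound 3 `C=C(C)[C@H]1CC[C@@]2(C)CCC[C@@](C)(N=C=S)[C@@H]2C1` also stops at a limit, > 20 ug/mL. All three values shown thus sit at the limit of > 20 ug/mL in this assay, at which 3 of the 3 values shown sit, and no number places compound 3 against the others.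

Compound 4 `C=C(C)[C@@H]1CC[C@@]2(C)CCC[C@@](C)(N=C=S)[C@@H]2C1` differs from compound 3 by the two compounds have the same atoms and bonds; at least one stereo element is drawn with a configuration in one of them and without one in the other: 1 of 5 stereo elements differ; a stereocentre at a saturated ring carbon is drawn S in compound 3 and R in compound 4. No measured step bears directly on this change; the single step shown is unreadable, and every value is a limit. Nothing measured points to a shift beyond the scatter. The step from compound 3 is expected to be a step that the limit leaves unreadable from compound 3 to compound 4. Compound 4 is accordingly estimated at 30 ug/mL, with a range from 15 ug/mL to 60 ug/mL, most likely reported again as a limit.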

Compound 4, half-maximal inhibitory concentration: > 20 ug/mL
Compound 4: no number, only a limit; the forecaster's own chance of this, stated with the estimate: 85%; the middle value lies beyond the limit too.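

In this assay, going by these compounds alone, compound 4 gives only a limit, > 20 ug/mL, and compound 3 also stops at a limit, so no step between compound 3 and compound 4 can be read. The compounds shown leave open whether the stereocentre drawn S in compound 3 and R in compound 4 changes the read-out at all, and how any compound shown ranks against the others: the limit of > 20 ug/mL in this assay, at which 4 of the 4 values shown sit.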